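A few compounds are considered here, and "the series" means these few. Any claim that something is new, unique, unknown or untested is made for them only; others in the source may bear on it.

Compound 3 `CCCCCc1ccc(C#Cc2cn(C/C=C/CN3C(=O)c4ccccc4C3=O)c(=O)[nH]c2=O)cc1` gives 23000 nM in a functional assay on CCRF-CEM cells (Homo sapiens) for antiproliferative activity, read by MTT assay, with a stated time of 3 days (a lower number here means a stronger inhibitor, a higher number a weaker inhibitor), the lowest of the three numbers measured. Compound 2 `O=C1c2ccccc2C(=O)N1C/C=C/Cn1cc(C#CCCc2ccccc2)c(=O)[nH]c1=O` gives 38000 nM in this assay, and the two lie within the scatter of each other. Compound 1 `CCCCC#Cc1cn(C/C=C/CN2C(=O)c3ccccc3C2=O)c(=O)[nH]c1=O` gives 192000 nM, the highest. Compound 4 `CCCCCC#Cc1cn(C/C=C/CN2C(=O)c3ccccc3C2=O)c(=O)[nH]c1=O` differs from compound 3 in one place: pentyl in place of 4-pentylphenyl on a triple-bonded carbon. The step that bears on this is an 8.3-fold lower number from compound 1 to compound 3 (0.92 log units; beyond the scatter), which runs the other way, putting a ring onto the triple-bonded carbon in place of a chain; compound 4 carries a chain there again, one carbon longer than compound 1. A step of roughly that size back towards a higher number is therefore expected, a 6.5-fold higher number from compound 3 to compound 4 (0.81 log units; beyond the scatter). Compound 4 is expected to give about 150000 nM, within 50000 nM to 450000 nM.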

Compound 4, half-maximal inhibitory concentration: > 500000 nM
Compound 4 gave a limit, no number; the forecaster's own chance of this, stated with the estimate: 15%; at least 3.3-fold (0.52 log units) between middle value and limit.
By their numbers in this assay, from the lowest: compounds 3 and 2 (each within the scatter of the next); then compound 1. At a limit, above all of these: compound 4.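

In this assay compound 4 gives > 500000 nM, which is a limit of the assay and not a number. Without a ring in the group on the triple-bonded carbon, the number rises sharply, with an at least 21-fold higher number from compound 3 to compound 4 (1.33 log units; beyond the scatter) and an at least 13-fold higher number from compound 2 to compound 4 (1.11 log units; beyond the scatter). Lengthening the plain chain by one carbon brings no gain either, with an at least 2.6-fold higher number from compound 1 to compound 4 (0.41 log units; beyond the scatter). The compounds shown do not tell why a ring matters here. From the compounds shown here alone, whether an amine or a carboxylic acid at the end of the chain would lower the number remains open.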